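Chloro Added to Compound 1: Tolerance Expected to Stay High

This account rests on a few compounds, and the source may have more. Where it says the series, first, only, none or still open, it means among the compounds named here.

Two compounds have been measured in an ADME assay on HEK293 cells (Homo sapiens) for cytotoxicity, read by reporter gene assay and resazurin assay, with a stated time of 48 h; a lower number here means that less compound is tolerated, a higher number that more compound is tolerated:

Compound 1, `COc1c(Br)cc(Br)cc1C(=O)Nc1ccccc1`, gives a limit of > 100000 nM in this assay.
Compound 2, `COc1c(Br)cccc1C(=O)Nc1ccccc1`, gives a limit of > 100000 nM in this assay.

Compound 1 therefore stands only at a limit of this assay, and no number below that limit is known for it. For the measured compounds named here, the single measured step, a step that the two limits leave unreadable from compound 1 to compound 2, is hydrogen in place of bromo on an aromatic carbon, and because both ends sit at the limit of > 100000 nM in this assay, at which 2 of the 2 values shown sit, its size cannot be read.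

Compound 3, `COc1c(Br)cc(Br)cc1C(=O)Nc1cccc(Cl)c1`, differs from compound 1 by chloro in place of hydrogen on an aromatic carbon. Going by the values given here, no measured step touches that ring or involves chloro, so nothing here speaks for a change in either direction, and the one step on record is unreadable anyway. The expectation is that compound 3 will again reach the limit of this assay, so that a number no higher from compound 1 to compound 3 (the limit leaves the size open) is expected to show no step beyond the scatter. For compound 3 an estimated value of 100000 nM is expected, with a range from 40000 nM to 250000 nM.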

Compound 3, half-maximal cytotoxic concentration: > 100000 nM
Compound 3: no number, only a limit; the forecaster's own chance of this, stated with the estimate: 80%; the middle value sits exactly at the limit.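

In this assay compound 3 gives > 100000 nM as a limit and not a number, so no step can be read between compound 1 and compound 3. The compounds shown leave open at what concentration, if any, compound 1, compound 2 or compound 3 would become cytotoxic, and whether either exchange alters tolerance at all.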